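A few compounds are considered here, and "the series" means these few. Any claim that something is new, unique, unknown or untested is made for them only; others in the source may bear on it.

Measured so far in an assay on HEK293 cells for displacement of a labelled ligand from prostaglandin D2 receptor 2 (Homo sapiens); a lower number here means a stronger inhibitor, a higher number a weaker inhibitor:
compound 1, `O=C(O)Cn1c(SCc2cccc(Cl)c2)nc2ccccc21`, gives 186 nM;
compound 2, `O=C(O)Cn1c(SCc2cccc(Br)c2)nc2ccccc21`, gives 370 nM.

Among the measured compounds shown here, compound 2 stands at the highest of these two numbers, though the only measured step, a 2.0-fold higher number from compound 1 to compound 2 (0.30 log units; within the scatter), lies within the scatter, so the two compounds cannot be ordered against each other. Compound 3, `O=C(O)Cn1c(SCc2ccccc2Br)nc2ccccc21`, has the same atoms as compound 2 joined differently: 2-bromophenyl in place of 3-bromophenyl on a saturated chain carbon bound to a sulfur. For the measured compounds named here, no measured step bears on moving the bromine to another ring position; the single step available concerns exchanging one halogen for another at the same position, and that step stayed within the scatter. With nothing pointing in either direction, compound 3 is expected to land close to compound 2, with no step beyond the scatter anticipated, as no change at the digits printed from compound 2 to compound 3 (within the scatter). In this assay compound 3 is therefore estimated at 370 nM, in a range from 120 nM to 1200 nM.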

Compound 3, half-maximal inhibitory concentration: 580 nM
Compound 3: the middle estimate sits 1.6-fold (0.20 log units) below what was measured; measured number inside the range.
By their numbers in this assay, from the lowest: compounds 1, 2 and 3 (each within the scatter of the next, the first and the last beyond it).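

In this assay, exchanging 3-bromophenyl for 2-bromophenyl on a saturated chain carbon bound to a sulfur gives a 1.6-fold higher number from compound 2 to compound 3 (0.20 log units; within the scatter), so the compounds shown do not separate these two placements of the bromine. The combined change of 3-chlorophenyl to 2-bromophenyl gives a 3.1-fold higher number from compound 1 to compound 3 (0.49 log units; beyond the scatter), the only step among these compounds that clears the scatter, although each of the two single steps linking them stays inside it. Nothing available offers an explanation for this modest difference.

On these data alone, it remains open whether a plain phenyl, or a methoxy or nitrile group in place of the halogen, would stay within this narrow band of values. Also open, as far as these compounds go, is what an oxygen in place of the sulfur would do to the number in this assay when the rest of the structure is kept.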